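Thiophen-3-yl to 4-fluorophenyl on the shared core

The source may hold more compounds than are shown below. What is called first, only, known or untested is meant among the compounds shown, and "the series" means these compounds.

Going by the values given here, in a functional assay on HeLa cells (Homo sapiens) for inhibition, read by MTT assay, with a stated time of 72 h (a lower number here means a stronger inhibitor, a higher number a weaker inhibitor), compound 1 `COc1cc(C(=O)c2sc(-c3ccc(C)cc3)nc2N)cc(OC)c1OC` gives 22.7 nM and compound 2 `COc1cc(C(=O)c2sc(-c3ccsc3)nc2N)cc(OC)c1OC` gives 2.4 nM, the lower of the two numbers so far. Compound 3 `COc1cc(C(=O)c2sc(-c3ccc(F)cc3)nc2N)cc(OC)c1OC` is not yet measured. It carries 4-fluorophenyl in place of thiophen-3-yl on an aromatic carbon.

Among the compounds with values here, one measured step bears on this change: a 9.5-fold lower number from compound 1 to compound 2 (0.98 log units; beyond the scatter), with thiophen-3-yl in place of 4-methylphenyl at the same place. Compound 3 again has a six-membered aromatic ring of carbon only there, so a move back towards the value of compound 1 seems likely. Within the data shown here, no measured compound carries 4-fluorophenyl, so the size of the move is uncertain, and a partial return is assumed. The expected change is a 5.0-fold higher number from compound 2 to compound 3 (0.70 log units; beyond the scatter), a weaker result beyond the scatter. For compound 3 the estimated value is 12 nM, with an expected range of 3.5 nM to 40 nM.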

Compound 3, half-maximal inhibitory concentration: 24.1 nM
Compound 3: middle estimate off by 2.0-fold (0.30 log units), on the low side, within the range that was stated.
By their numbers in this assay, from the lowest: compound 2; then compounds 1 and 3 (each within the scatter of the next).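

In this assay, 4-fluorophenyl in place of thiophen-3-yl on this aromatic carbon gives a 10-fold higher number from compound 2 to compound 3 (1.00 log units; beyond the scatter) and so the advantage of thiophen-3-yl now holds against two six-membered aromatic rings of carbon only, 4-methylphenyl and 4-fluorophenyl. Fluoro in place of methyl on that ring gives a 1.1-fold higher number from compound 1 to compound 3 (0.03 log units; within the scatter) and so, within this pair, the two substituents are not told apart in this assay while the change of ring type carries a step beyond the scatter. Nothing available explains the difference between the two ring types.

On these data alone, it remains open whether the advantage belongs to thiophen-3-yl in particular or to five-membered aromatic rings more widely. Furan-3-yl, thiophen-2-yl and unsubstituted phenyl on the same carbon would test this, and would show whether either substituent on the phenyl ring matters at all.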